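Lipophilicity notes: pyridin-3-yl for benzoyl on the amine

A few compounds are considered here, and "the series" means these few. Any claim that something is new, unique, unknown or untested is made for them only; others in the source may bear on it.

Measured so far:
compound 1 `CC1(C)CC(=O)N(c2cnc(NCc3c(F)ccc4c3CCO4)n3cnnc23)C1` — 2
compound 2 `CN(C(=O)c1ccccc1)c1cnc(NCc2c(F)ccc3c2CCO3)n2cnnc12` — 2.4

In a physicochemical assay for lipophilicity, using the shake flask method, in phosphate buffer, measured as octanol-water partition, with a stated time of 30 min, at pH 7.4 (on this read-out higher numbers stand for higher lipophilicity and lower numbers for lower lipophilicity), compound 2 gives 2.4, the higher of the two numbers; compound 1 gives 2, and the step of a number 0.40 log units higher from compound 1 to compound 2 (beyond the scatter) is beyond the scatter. Compound 3 `CN(c1cccnc1)c1cnc(NCc2c(F)ccc3c2CCO3)n2cnnc12` differs from compound 2 by pyridin-3-yl in place of benzoyl on a nitrogen on an aromatic ring. For the measured compounds named here, no measured step covers this change directly; the one step known, from compound 1 to compound 2, swaps the whole substituent and so offers only a loose bound on its size. The step of a number 0.10 log units higher from compound 2 to compound 3 (within the scatter) is therefore expected to stay small and within the scatter. Compound 3 is estimated at 2.5, in the range 1.9 to 3.1.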

Compound 3, distribution coefficient: 2.6
For compound 3 the middle estimate is 0.10 log units below the measured one; measured number inside the range.
By their numbers in this assay, from the lowest: compound 1; then compounds 2 and 3 (each within the scatter of the next).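

In this assay, pyridin-3-yl in place of benzoyl on this nitrogen gives a number 0.20 log units higher from compound 2 to compound 3 (within the scatter) for the step, so exchanging the carbon-only ring and carbonyl for a ring with one hetero atom leaves the read-out unresolved. Replacing 4,4-dimethyl-2-oxopyrrolidin-1-yl with methyl(pyridin-3-yl)amino gives a number 0.60 log units higher from compound 1 to compound 3 (beyond the scatter), a step that the benzoyl(methyl)amino group also exceeds the scatter on. Nothing available explains either step.

Going by these compounds, it remains open whether a saturated amine or a carboxylic acid on this nitrogen would move the number beyond the scatter of compound 2. On these data alone, the contribution of the methyl on this nitrogen also remains open.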